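Acylcarbamoyl Group Returns to the Amine Nitrogen

The source may hold more compounds than are shown below. What is called first, only, known or untested is meant among the compounds shown, and "the series" means these compounds.

Two silyl-protected nucleoside analogues built on one shared core were examined in a functional assay on HEL cells (Homo sapiens) for cytotoxicity, read by microscopy; on this read-out lower numbers stand for higher toxicity in this test and higher numbers for lower toxicity in this test. Compound 1 `CCOC(=O)NC(=O)NC1=CS(=O)(=O)O[C@@]12[C@@H](CO[Si](C)(C)C(C)(C)C)O[C@@H](n1cc(C)c(=O)n(C)c1=O)[C@@H]2O[Si](C)(C)C(C)(C)C` gives 16000 nM. Compound 2 `COC(=O)CNC1=CS(=O)(=O)O[C@@]12[C@@H](CO[Si](C)(C)C(C)(C)C)O[C@@H](n1cc(C)c(=O)n(C)c1=O)[C@@H]2O[Si](C)(C)C(C)(C)C` reaches only the limit of the test, >= 400000 nM, which is a limit and not a measured number. Within the data shown here, the step of an at least 25-fold higher number from compound 1 to compound 2 (1.39 log units; beyond the scatter) is the single measured comparison in the set. Compound 2 therefore stands at the limit of >= 400000 nM in this assay, at which 1 of the 2 values shown sits, so its cytotoxicity cannot be placed more exactly than that.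

Compound 3 `C=C(C)C(=O)NC(=O)NC1=CS(=O)(=O)O[C@@]12[C@@H](CO[Si](C)(C)C(C)(C)C)O[C@@H](n1cc(C)c(=O)n(C)c1=O)[C@@H]2O[Si](C)(C)C(C)(C)C` differs from compound 2 by ((1-methylethenyl)carbonyl)carbamoyl in place of (methoxycarbonyl)methyl on an amine nitrogen. The group that enters is again an acylated carbamoyl on the amine nitrogen, the kind of substituent compound 1 carries, so the step of an at least 25-fold higher number from compound 1 to compound 2 (1.39 log units; beyond the scatter) bears on this change when read in the opposite direction. Compound 3 is thus expected to regain a measurable cytotoxic concentration in the region occupied by compound 1. Compound 3 is expected to show a step of an at least 20-fold lower number from compound 2 to compound 3 (1.30 log units; beyond the scatter) in this assay. The estimate for compound 3 is 20000 nM, with a range from 5000 nM to 100000 nM.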

Compound 3, minimum cytotoxic concentration: 20000 nM
The estimate for compound 3 equals the measured number at the digits printed; the range from low to high includes it.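

In this assay, the result shows that the low number of compound 1 is not tied to (ethoxycarbonyl)carbamoyl alone: a second acylated carbamoyl on the amine nitrogen, ((1-methylethenyl)carbonyl)carbamoyl, gives an at least 20-fold lower number from compound 2 to compound 3 (1.30 log units; beyond the scatter). The far end of this substituent can also be changed without a readable effect in this test, as 1-methylethenyl in place of ethoxy on a carbonyl carbon gives a 1.3-fold higher number from compound 1 to compound 3 (0.10 log units; within the scatter). The value of compound 2 remains a limit and not a number, so the large step away from it has no exact size: the limit of >= 400000 nM in this assay, at which 1 of the 3 values shown sits.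

What a plain carbamoyl, an acetyl or a free amine on the same nitrogen would give stays open, so the compounds shown cannot say whether the whole acylated carbamoyl is needed for the lower number or only part of it. Every compound shown also keeps both tert-butyldimethylsilyl groups on the shared core, which leaves open whether the same step would appear with free hydroxyl groups in their place.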